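Compound 4: one hydroxy fewer than compound 3

The source may hold more compounds than are shown below. What is called first, only, known or untested is meant among the compounds shown, and "the series" means these compounds.

In a physicochemical assay for lipophilicity, measured as octanol-water partition (on this read-out lower numbers stand for lower lipophilicity and higher numbers for higher lipophilicity), compound 1 `C/C(=N\NC(=O)COc1cccc2ccccc12)c1ccc([N+](=O)[O-])cc1` gives 3.37, compound 2 `C/C(=N\NC(=O)COc1cccc2ccccc12)c1ccc(Cl)cc1` gives 4.17 and compound 3 `C/C(=N\NC(=O)COc1cccc2ccccc12)c1ccc(O)cc1O` gives 4.31. Compound 3 cannot be told apart from compound 2, and both lie clear of compound 1. Compound 4 `C/C(=N\NC(=O)COc1cccc2ccccc12)c1ccccc1O` differs from compound 3 by hydrogen in place of hydroxy on an aromatic carbon, turning 2,4-dihydroxyphenyl into 2-hydroxyphenyl. Among the measured compounds shown here, no measured step isolates this change. The nearest evidence is a number 0.14 log units higher from compound 2 to compound 3 (within the scatter) and a number 0.94 log units higher from compound 1 to compound 3 (beyond the scatter), and each of these exchanges a whole substituted phenyl. A single hydroxy is therefore expected to move this assay little, with no step beyond the scatter. The expected change is a number 0.19 log units higher from compound 3 to compound 4 (within the scatter). For compound 4 the estimate is 4.5, within an expected range of 4 to 5.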

Compound 4, partition coefficient: 3.08
Compound 4: the middle estimate sits 1.42 log units above what was measured; measured number below the stated range.
By their numbers in this assay, from the lowest: compounds 4 and 1 (each within the scatter of the next); then compounds 2 and 3 (each within the scatter of the next).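

In this assay, the hydroxy on this aromatic carbon, para to a large group, proves decisive: hydrogen in its place gives a number 1.23 log units lower from compound 3 to compound 4 (beyond the scatter), so the whole-ring exchanges had not shown what this one group can do. The 2-hydroxyphenyl also stands clear of 4-chlorophenyl, with a number 1.09 log units lower from compound 2 to compound 4 (beyond the scatter), yet against 4-nitrophenyl there is only a number 0.29 log units lower from compound 1 to compound 4 (within the scatter), a gap that separates nothing. No supporting measurement accounts for the size of this step. Left open is whether an amine or a carboxylic acid on this same aromatic carbon would read like hydroxy or like hydrogen, and whether the step would hold without the remaining hydroxy.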